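Swapping the oxime for a chlorovinyl on the deoxyuridine core

The source may hold more compounds than are shown below. What is called first, only, known or untested is meant among the compounds shown, and "the series" means these compounds.

Measured so far, in an ADME assay on L1210/0 cells (Mus musculus) for cytotoxicity, with a stated time of 48 h; a higher number here means a weaker inhibitor, a lower number a stronger inhibitor:
- compound 1 `O=c1[nH]c(=O)n([C@H]2C[C@H](O)[C@@H](CO)O2)cc1/C=N/O`: compound 1 gives 15500 nM
- compound 2 `C#Cc1cn([C@@H]2O[C@H](CO)[C@@H](O)[C@@H]2O)c(=O)[nH]c1=O`: compound 2 gives 168000 nM
- compound 3 `CCCNc1ncnc2c1ncn2C[C@@H]1C[C@H](CO)c2ccccc21`: compound 3 gives only a limit, > 200000 nM

Among the numbers shown, compound 1 stands lowest; the nearest, compound 2, sits at a higher value, beyond the scatter. The value for compound 3 is a limit of this assay, as in the limit of > 200000 nM in this assay, at which 1 of the 3 values shown sits, and is not a number.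

The step of interest leads from compound 1 to compound 4 `O=c1[nH]c(=O)n([C@H]2C[C@H](O)[C@@H](CO)O2)cc1/C=C/Cl`. The change is a group of 3 heavy atoms (2 carbon, 1 chlorine; no ring) in place of a group of 3 heavy atoms (1 carbon, 1 nitrogen, 1 oxygen; no ring), on an aromatic carbon. Among the compounds with values here, no measured pair in this set shares such a step, so the expectation rests on compound 1 alone and on the change itself. The chlorovinyl group is expected to leave the value of compound 1 roughly unchanged or to move it upward by a modest amount, and a step of a 2.6-fold higher number from compound 1 to compound 4 (0.41 log units; beyond the scatter) is estimated. Compound 4 is therefore expected to give about 40000 nM, within a range from 10000 nM to 200000 nM.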

Compound 4, half-maximal inhibitory concentration: > 200000 nM
Compound 4 was reported as a limit; the forecaster's own chance of this, stated with the estimate: 15%; middle value at least 5.0-fold (0.69 log units) from the limit.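

At this aromatic carbon of the shared core, this assay records an at least 12-fold higher number from compound 1 to compound 4 (1.11 log units; beyond the scatter), so this position does not tolerate every group of its size: the 2-chloroethenyl group has the same number of heavy atoms as the oxime it replaces, yet cytotoxicity falls sharply. The group that leaves carries a hydrogen-bond donor and hydrogen-bond acceptors and the group that enters carries neither, though this single step cannot show that this difference is what matters. The value of compound 4 is a limit and not a number: the limit of > 200000 nM in this assay, at which 2 of the 4 values shown sit.

Going by these compounds, the true size of the step therefore stays open, as does which feature of the oxime supports the value of compound 1. Also open, on these data alone, is how an amine, a carboxylic acid or a longer chain at this carbon would behave.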